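Amide side-chain swap in the phosphofructokinase inhibitor series

This account rests on a few compounds, and the source may have more. Where it says the series, first, only, none or still open, it means among the compounds named here.

Going by the values given here, compound 3 `Cn1cc(CNC(=O)c2ccncc2Nc2cc(-c3ccc4ccn(C)c4c3)c3nccnc3c2)cn1` stands second highest of the three numbers so far in an assay for inhibition of 6-phosphofructo-2-kinase/fructose-2,6-bisphosphatase 3 (Homo sapiens), read by ADP-Glo, with a stated time of 2 h; a lower number here means a stronger inhibitor, a higher number a weaker inhibitor: compound 3 gives 159 nM, while compound 2 `Cn1ccc2ccc(-c3cc(Nc4ccccc4S(=O)(=O)N4CCOCC4)cc4nccnc34)cc21` gives 36 nM and compound 1 `Cn1ccc2ccc(-c3cc(Nc4ccccc4S(=O)(=O)Nc4cncnc4)cc4nccnc34)cc21` gives 1690 nM. Among the compounds with values here, the only single-point step measured to date lies in the sulfonamide pair, a 47-fold lower number from compound 1 to compound 2 (1.67 log units; beyond the scatter), where a saturated six-membered amine replaced an aromatic amino group on the sulfonyl sulfur. Compound 4 `CC(=O)N1CCOC(CNC(=O)c2ccncc2Nc2cc(-c3ccc4ccn(C)c4c3)c3nccnc3c2)C1` is the amide counterpart: 4-acetylmorpholin-2-yl in place of 1-methyl-1H-pyrazol-4-yl on a saturated chain carbon bound to an amide-type nitrogen. Within the data shown here, the measured step sits on a different functional group and on a differently linked chain, so it bears only loosely on this change; the pair of compound 2 and compound 3 shows that the amide series runs weaker than the best sulfonamide, but no step is defined for it. For compound 4 a step within the scatter is expected, a 1.3-fold higher number from compound 3 to compound 4 (0.10 log units; within the scatter), since nothing measured here predicts the direction. Compound 4 is estimated at 200 nM in this assay, within 60 nM to 650 nM.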

Compound 4, half-maximal inhibitory concentration: 93 nM
Compound 4: the middle estimate sits 2.2-fold (0.33 log units) above what was measured, and the stated range covers the measured number.
By their numbers in this assay, from the lowest: compound 2; then compounds 4 and 3 (each within the scatter of the next); then compound 1.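

At the saturated chain carbon bound to an amide-type nitrogen, 4-acetylmorpholin-2-yl in place of 1-methyl-1H-pyrazol-4-yl gives a 1.7-fold lower number from compound 3 to compound 4 (0.23 log units; within the scatter) in this assay and provides the first readable step within the amide series. This position therefore accepts a six-membered non-aromatic ring in place of a five-membered aromatic ring with no change beyond the scatter, although this rests on a single pair. No supporting evidence is available to explain the result.

On these data alone, it remains open whether the unacetylated morpholin-2-yl group would give a number that differs beyond the scatter from that of compound 4. Also open, as far as these compounds go, is how a primary amine, a carboxylic acid or a longer alkyl chain would read at the same chain carbon.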